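Removing both chlorines from a triazole-linked phenyl ring

A few compounds are considered here, and "the series" means these few. Any claim that something is new, unique, unknown or untested is made for them only; others in the source may bear on it.

Within the data shown here, the two compounds measured so far share a core carrying a trimethoxyphenyl group on a five-membered aromatic ring with three nitrogen atoms, and differ only in the aryl group on the remaining ring carbon. Compound 1 `COc1cc(-n2ncnc2-c2ccc(OC(F)(F)F)cc2)cc(OC)c1OC` bears a trifluoromethoxyphenyl group. In a functional assay on K562 cells (Homo sapiens) for antiproliferative activity, read by MTT assay, with a stated time of 72 h (a lower number here means a stronger inhibitor, a higher number a weaker inhibitor), compound 1 gives only a limit, > 10000 nM, and no number. Compound 2 `COc1cc(-n2ncnc2-c2ccc(Cl)c(Cl)c2)cc(OC)c1OC` carries a 3,4-dichlorophenyl group. In this assay compound 2 likewise reaches only a limit, > 10000 nM. Among the measured compounds shown here, both values therefore sit at the same boundary, (the limit of > 10000 nM in this assay, at which 2 of the 2 values shown sit), so nothing separates compound 1 from compound 2 in this assay, and no step between measured compounds can be drawn.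

Compound 3 `COc1cc(-n2ncnc2-c2ccccc2)cc(OC)c1OC` is the next member. It differs from compound 2 in one place: phenyl in place of 3,4-dichlorophenyl on an aromatic carbon.

Given that compound 2 shows only a limit in this assay, > 10000 nM, the expected step that the limit leaves unreadable from compound 2 to compound 3 is most likely none beyond the scatter, with the result again at the boundary. Compound 3 is estimated to give 15000 nM in this assay, within a range from 5000 nM to 50000 nM.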

Compound 3, half-maximal inhibitory concentration: > 10000 nM
Compound 3: a limit, no number; the forecaster's own chance of this, stated with the estimate: 80%; the middle value is on the limit's open side.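

In this assay compound 3 gives only a limit, > 10000 nM. No step from compound 1 or compound 2 to compound 3 can be read, and all three compounds stand at one boundary: the limit of > 10000 nM in this assay, at which 3 of the 3 values shown sit.

The compounds shown leave open how the trifluoromethoxyphenyl, 3,4-dichlorophenyl and phenyl groups compare in this assay, and whether any group on the shared core gives a readable number there.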